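The source may hold more compounds than are shown below. What is called first, only, known or untested is meant among the compounds shown, and "the series" means these compounds.

Compound 1 `C[C@@H]1[C@H](C(=O)O)[C@H]1C(C)(N)C(=O)O`: > 10000 nM
Compound 2 `C[C@@H]1[C@H](C(=O)O)[C@H]1C(N)(CCc1ccccc1)C(=O)O`: 5070 nM

Among the compounds with values here, in a functional assay (membranes, forebrain) for antagonist activity, with Rattus norvegicus as the target (a lower number here means a stronger inhibitor, a higher number a weaker inhibitor), compound 2 gives 5070 nM, the only actual number so far. The entry for compound 1, > 10000 nM, is a limit of the assay. Compound 3 `NC(CCc1ccccc1)(C(=O)O)[C@H]1[C@H](CCc2ccccc2)[C@@H]1C(=O)O` changes compound 2 as follows: benzyl in place of hydrogen on a saturated chain carbon bound to a saturated ring carbon. This places benzyl in place of hydrogen on a saturated chain carbon bound to a saturated ring carbon. Within the data shown here, no measured step covers this change, so only a small shift towards weaker inhibition in this assay is expected. The estimated change is a 1.4-fold higher number from compound 2 to compound 3 (0.14 log units; within the scatter). For compound 3 the expected value is 7000 nM, with an estimated range of 2000 nM to 25000 nM.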

Compound 3, half-maximal inhibitory concentration: 2540 nM
Beside the measured number, compound 3's estimate is 2.8-fold (0.44 log units) above it, and the stated range covers the measured number.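

In this assay, methyl to phenethyl at this place on the shared core gives a 2.0-fold lower number from compound 2 to compound 3 (0.30 log units; within the scatter). Within the data shown here, this is the first step at this position read between two actual numbers, and it shows that phenethyl is carried here with no change beyond the scatter. Compound 1 cannot add a further step, as its entry is a limit of the assay: the limit of > 10000 nM in this assay, at which 1 of the 3 values shown sits.

From the compounds shown here alone, whether an amine, a carboxylic acid or a longer chain in place of phenethyl would move the number beyond the scatter stays open.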